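Moving the methyl around the benzamide ring

The source may report more compounds than this note shows. Statements on the series, on what has been measured and on what is new or still open speak of the compounds shown alone.

Compound 1 `COc1ccc(-c2ccnc(NC(=O)c3ccc(F)cc3)c2)cc1` reaches only a limit in a toxicity assay on THP-1 cells (Homo sapiens) for inhibition (on this read-out lower numbers stand for higher toxicity in this test and higher numbers for lower toxicity in this test), where compound 1 gives > 100000 nM. Compound 2 `Cn1c(-c2ccccc2)cnc1NC(=O)c1cccc(Cl)c1` also sits at a limit, giving > 50000 nM in this assay. Compound 3 `Cc1ccccc1C(=O)Nc1ncc(-c2ccccc2)n1C` likewise returns a limit of > 100000 nM in this assay. For the measured compounds named here, the one measured step, a step that the two limits leave unreadable from compound 2 to compound 3, is therefore unreadable between its two limits, as the limit of > 100000 nM in this assay, at which 2 of the 3 values shown sit, and the limit of > 50000 nM in this assay, at which 1 of the 3 values shown sits, show. Compound 4 `Cc1ccc(C(=O)Nc2ncc(-c3ccccc3)n2C)cc1` differs from compound 3 by 4-methylphenyl in place of 2-methylphenyl on a carbonyl carbon. Going by the values given here, no measured step speaks to this change, and every value shown is a limit, so no movement beyond the scatter is expected in this assay. The expected step that the limit leaves unreadable from compound 3 to compound 4 is accordingly flat. Compound 4 is thus expected to give 150000 nM, between 50000 nM and 500000 nM, most likely again as a limit.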

Compound 4, half-maximal cytotoxic concentration: > 50000 nM
Compound 4 gave a limit, no number; the forecaster's own chance of this, stated with the estimate: 85%; the middle value lies beyond the limit too.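

Compound 4 gives > 50000 nM in this assay, which is a limit and not a number, so its steps from compound 2 and from compound 3 cannot be read. The compounds shown leave open whether swapping 2-methylphenyl for 4-methylphenyl changes toxicity in this assay at all.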